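From compound 3 to compound 4: chloro for trifluoromethoxy

This account rests on a few compounds, and the source may have more. Where it says the series, first, only, none or still open, it means among the compounds named here.

In a physicochemical assay for solubility, at pH 7.4 (a lower number here means a less soluble compound, a higher number a more soluble compound), compound 3 (`Cc1cc(NC(=O)Nc2ccc(OC(F)(F)F)cc2)c2ccccc2n1`) gives 300 nM, level with compound 1 (`Cc1cc(NC(=O)Nc2ccc(Cl)c(Cl)c2)c2ccccc2n1`) at 300 nM, while compound 2 (`Cc1cc(NC(=O)Nc2ccc(C(F)(F)F)cc2)c2ccccc2n1`) gives 100 nM. Compound 4 (`Cc1cc(NC(=O)Nc2ccc(Cl)cc2)c2ccccc2n1`) has chloro in place of trifluoromethoxy on an aromatic carbon, para to a large group: chloro in place of trifluoromethoxy on an aromatic carbon. Among the measured compounds shown here, the one measured step at this place is a 3.0-fold higher number from compound 2 to compound 3 (0.48 log units; beyond the scatter), with trifluoromethoxy in place of trifluoromethyl. For the measured compounds named here, no measured step exchanges trifluoromethoxy for chloro directly. Compound 1 also carries chloro and matches compound 3, so no step beyond the scatter is expected, and no direction is favoured. The expected outcome is no change at the digits printed from compound 3 to compound 4 (within the scatter). Compound 4 is estimated at 300 nM, within an expected range of 100 nM to 800 nM.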

Compound 4, solubility: 1400 nM
For compound 4 the middle estimate is 4.7-fold (0.67 log units) below the measured one; the whole stated range lies below it.
By their numbers in this assay, from the lowest: compound 2; then compounds 1 and 3 (each within the scatter of the next); then compound 4.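

Chloro at this position gives a clearly higher number in this assay than either fluorinated group, with a 4.7-fold higher number from compound 3 to compound 4 (0.67 log units; beyond the scatter) and a 14-fold higher number from compound 2 to compound 4 (1.15 log units; beyond the scatter) as the two steps, the second of them large. The extra chloro of compound 1 does not help either: a 4.7-fold higher number from compound 1 to compound 4 (0.67 log units; beyond the scatter) comes with hydrogen in its place. Nothing measured on hand accounts for these steps.

Still open, going by these compounds, is where hydrogen alone at this position would fall, and whether an amine or a carboxylic acid there would exceed chloro.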